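Swapping Chloro for Bromo in Compound 1

The compounds below may be only part of what the source reports. "The series", "measured", "known", "first", "only" and "open" are said of these compounds alone.

Of the compounds shown here, three have been measured in a functional assay on HL-60 cells (Homo sapiens) for cytotoxicity, read by luminescence and CellTiter-Glo, with a stated time of 3 days; a higher number here means a weaker inhibitor, a lower number a stronger inhibitor. Compound 1 `N#Cc1ccc(NC(=O)c2ccc(Cl)cc2O)cc1` gives 1300 nM, the highest of the three numbers. Compound 2 `O=C(Nc1ccc(C(F)(F)F)cc1)c1ccc(Cl)cc1O` gives 630 nM and compound 3 `O=C(Nc1ccc(Cl)cc1Cl)c1ccc2cccnc2c1O` gives 610 nM in this assay. Going by the values given here, the single step between compounds that differ in one place runs a 2.1-fold lower number from compound 1 to compound 2 (0.31 log units; beyond the scatter). Compound 4 `N#Cc1ccc(NC(=O)c2ccc(Br)cc2O)cc1` differs from compound 1 by bromo in place of chloro on an aromatic carbon. Among the compounds with values here, no measured step bears directly on this change: the step from compound 1 to compound 2 alters a different part of the molecule, so the numbers at hand say nothing about a halogen exchange at this place. Compound 4 is therefore expected to stay close to compound 1. The expected step is a 1.3-fold lower number from compound 1 to compound 4 (0.11 log units; within the scatter), not necessarily beyond the scatter. The estimate for compound 4 is 1000 nM, within a range from 450 nM to 2500 nM.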

Compound 4, half-maximal inhibitory concentration: 1210 nM
The estimate for compound 4 lay 1.2-fold (0.08 log units) below the measured number; measured number inside the range.
By their numbers in this assay, from the lowest: compounds 3, 2, 4 and 1 (each within the scatter of the next, the first and the last beyond it).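

In this assay, bromo in place of chloro on the aromatic carbon gives a 1.1-fold lower number from compound 1 to compound 4 (0.03 log units; within the scatter), so the two halogens cannot be told apart at this place in the core of compound 1. Going by these compounds alone, this is the first measured change at this position, as the earlier step altered a different part of the molecule. Nothing measured here accounts for this result.

From the compounds shown here alone, what remains open is whether an amine, a methoxy group or a carboxylic acid at this place would shift the number. Going by these compounds, it is also open whether bromo would behave the same way alongside the trifluoromethyl group of compound 2.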